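Acyclic side chain in place of the sugar on the core

This account rests on a few compounds, and the source may have more. Where it says the series, first, only, none or still open, it means among the compounds named here.

Working notes. For the measured compounds named here, compound 1 `NC(=O)c1nc(C#Cc2ccc(C(F)(F)F)cc2)n([C@@H]2O[C@H](CO)[C@@H](O)[C@H]2O)n1` is the only member of the set with a measured number in an ADME assay on Huh-5-2 cells (Homo sapiens) for cytotoxicity; a higher number here means that more compound is tolerated, a lower number that less compound is tolerated; compound 1 gives 82500 nM. Compound 2 `COC(=O)c1nc(C#CC2(O)CCCC2)n([C@@H]2O[C@H](COC(C)=O)[C@@H](OC(C)=O)[C@H]2OC(C)=O)n1` reaches only a limit in this assay, where compound 2 gives > 105000 nM. One of the two values shown is therefore a limit, (the limit of > 105000 nM in this assay, at which 1 of the 2 values shown sits). Compound 3 `NC(=O)c1nc(C#Cc2ccc(C(F)(F)F)cc2)n(COCCO)n1` differs from compound 1 by (2-hydroxyethoxy)methyl in place of 3,4-dihydroxy-5-(hydroxymethyl)oxolan-2-yl on an aromatic nitrogen. Going by the values given here, no step between measured compounds that differ in one place is available, so no shift beyond the scatter is assumed. Compound 3 is expected to give about 95000 nM, ranging from 45000 nM to 200000 nM. This estimate amounts to an expected step of a 1.2-fold higher number from compound 1 to compound 3 (0.06 log units; within the scatter), within the scatter.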

Compound 3, half-maximal cytotoxic concentration: 56500 nM
Compound 3: the middle estimate sits 1.7-fold (0.23 log units) above what was measured; the measured number falls inside the stated range.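

Exchanging 3,4-dihydroxy-5-(hydroxymethyl)oxolan-2-yl for the acyclic (2-hydroxyethoxy)methyl on the aromatic nitrogen gives, in this assay, a 1.5-fold lower number from compound 1 to compound 3 (0.16 log units; within the scatter), a step within the scatter. On the core of compound 1, this position therefore gives up the ring and its 4 defined stereocentres without a step beyond the scatter. Nothing shown bears on the reason for this result. Still open, as far as these compounds go, is whether a longer chain, or a chain bearing an amine or a carboxylic acid, on this aromatic nitrogen would also stay within the scatter of compound 1.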